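Swapping the aryl group on a quinazolinone urea series

This account rests on a few compounds, and the source may have more. Where it says the series, first, only, none or still open, it means among the compounds named here.

Three compounds share one core and differ only in the aryl group attached to the urea. Compound 1 `CCc1nc2ccccc2c(=O)n1NC(=O)Nc1ccccc1` gives, in a functional assay on the whole organism (strain albino) with Mus musculus as the target, at a dose of 100 mg/kg by the intraperitoneal route (on this read-out higher numbers stand for more inhibition at the one dose given (going by the name of the read-out) and lower numbers for less inhibition), 54%. Compound 2 `CCc1nc2ccccc2c(=O)n1NC(=O)Nc1ccc(C)cc1` gives in this assay 55%. Compound 3 `CCc1nc2ccccc2c(=O)n1NC(=O)Nc1ccc(OC)cc1` gives in this assay 48%. Compound 3 stands within the usual scatter of both companions: the change is a number 6 percentage points lower from compound 1 to compound 3 (within the scatter) and a number 7 percentage points lower from compound 2 to compound 3 (within the scatter), and also a number 1 percentage points higher from compound 1 to compound 2 (within the scatter) between the first two. So far, then, nothing about the group on the distal ring has moved the read-out beyond noise.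

Compound 4 `CCc1nc2ccccc2c(=O)n1NC(=O)Nc1ccccc1C` has not yet been measured. It differs from compound 3 as follows: 2-methylphenyl in place of 4-methoxyphenyl on an amide-type nitrogen. The measured steps that bear on this are the three substitutions on that same ring, each of them within the scatter. Within the data shown here, on that basis no step beyond the scatter is expected in this assay, and the value is estimated near the middle of the three known numbers. For compound 4 the expected result in this assay is 52%, with a range from 36% to 68%. That estimate means a step of a number 4 percentage points higher from compound 3 to compound 4 (within the scatter), which is expected to lie within the scatter.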

Compound 4, a percentage reported as inhibition, in the whole organism at one dose (the size of the read-out at that dose, not a potency): 54%
Estimate against measurement, compound 4: 2 percentage points below; the measured number falls inside the stated range.
By their numbers in this assay, from the lowest: compounds 3, 1, 4 and 2 (each within the scatter of the next).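

Placing the methyl group differently on the ring, as 2-methylphenyl in place of 4-methylphenyl on the amide-type nitrogen, gives in this assay a number 1 percentage points lower from compound 2 to compound 4 (within the scatter), so this read-out does not separate the two placements. Adding a methyl to the plain phenyl ring at the position of 2-methylphenyl gives no change at the digits printed from compound 1 to compound 4 (within the scatter), and the swap from 4-methoxyphenyl gives a number 6 percentage points higher from compound 3 to compound 4 (within the scatter), which leaves all four aryl groups within the scatter of one another. No measurement is at hand that would explain why these groups read alike.

From the compounds shown here alone, what remains open is whether a different kind of group on this ring, such as an amine or a carboxylic acid, would move the read-out beyond the scatter. Going by these compounds, a longer chain in place of the ethyl group on the shared core is equally open.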